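Methylsulfanyl in place of methyl on a triazole B-ring

A few compounds are considered here, and "the series" means these few. Any claim that something is new, unique, unknown or untested is made for them only; others in the source may bear on it.

Measured compounds:
compound 1, `COc1cc(-c2ncnn2-c2ccccc2)cc(OC)c1OC`, > 10000 nM in a functional assay on K562 cells (Homo sapiens) for antiproliferative activity, read by MTT assay, with a stated time of 72 h; on this read-out higher numbers stand for weaker inhibition and lower numbers for stronger inhibition
compound 2, `COc1cc(-n2ncnc2-c2ccc(C)cc2)cc(OC)c1OC`, > 10000 nM
compound 3, `CCOc1ccc(-c2ncnn2-c2cc(OC)c(OC)c(OC)c2)cc1Cl`, 20 nM

The series shares a trimethoxyphenyl group attached to a five-membered core, with a second aromatic ring on the other side. In this assay compound 1 gives only a limit of the assay, > 10000 nM. Compound 2 likewise gives only a limit, > 10000 nM, so no number is known for it, and it sits at the limit of > 10000 nM in this assay, at which 2 of the 3 values shown sit. Compound 3 differs from compound 2 in more than one place, and compound 3 gives 20 nM, a number rather than a limit; it shows that a compound built in this way can inhibit proliferation strongly.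

Compound 4, `COc1cc(-n2ncnc2-c2ccc(SC)cc2)cc(OC)c1OC`, is not yet measured. It comes from compound 2 by methylsulfanyl in place of methyl on an aromatic carbon.

Among the measured compounds shown here, no step between two measured compounds with a single difference is available, so the size of this step cannot be read from a measured pair. Given that compound 3 reaches 20 nM, the expectation is a step toward stronger inhibition beyond the scatter, of about an at least 50-fold lower number from compound 2 to compound 4 (1.69 log units; beyond the scatter). Compound 4 is therefore estimated at 200 nM, within a range from 20 nM to 3000 nM.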

Compound 4, half-maximal inhibitory concentration: 340 nM
Beside the measured number, compound 4's estimate is 1.7-fold (0.23 log units) below it; low and high end bracket the measured number.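

In this assay, among the compounds shown here, the change from methyl to methylsulfanyl, on an aromatic carbon para to a large group, gives an at least 29-fold lower number from compound 2 to compound 4 (1.46 log units; beyond the scatter), the first step that can be read across a single difference. For the compounds shown here, until now, the only compound with a number was compound 3, which differs from compound 2 in more than one place, so no single change could be linked to a gain in inhibition; now one small exchange on the 4-methylphenyl group is enough to turn a compound without a measurable number into compound 4, at 340 nM. The real size of the step stays unknown, and its printed size is only a lower bound, because compound 2 gives a limit of the assay and not a number: the limit of > 10000 nM in this assay, at which 2 of the 4 values shown sit.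

The compounds shown cannot separate the role of the sulfur atom from that of the longer group as a whole, a question that an ethyl group or an amine at the same place could help to answer. They also leave open whether the same exchange would give a step of similar size on the other compounds of the series, such as compound 1.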